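The compounds below may be only part of what the source reports. "The series", "measured", "known", "first", "only" and "open" are said of these compounds alone.

Compound 3 `O=C(O)c1ccc(-n2cc(C(=O)c3c(Cl)cccc3C(F)(F)F)c3cccnc32)c(F)c1` stands at 100% in an ADME assay on microsomes from liver (Homo sapiens) for metabolic stability, read by LC-MS, using NADPH, with stated times of 5 min and 30 min, tested at 1 uM (a lower number here means that less of the compound is left, a higher number that more of the compound is left), level with compound 1 `O=C(O)c1ccc(-n2cc(C(=O)c3c(Cl)cccc3Cl)c3cccnc32)cc1` at 100% and with compound 2 `O=C(O)c1ccc(-n2cc(C(=O)c3c(Cl)cccc3Cl)c3cccnc32)c(F)c1` at 100%. Compound 4 `O=C(O)c1ccc(-n2cc(C(=O)c3c(Cl)cccc3C(F)(F)F)c3cccnc32)cc1` differs from compound 3 by hydrogen in place of fluoro on an aromatic carbon. Of the measured steps, the step of no change at the digits printed from compound 1 to compound 2 (within the scatter) bears most directly on this change, since it runs the same exchange in the opposite direction at the same place and lies within the scatter. The step of no change at the digits printed from compound 2 to compound 3 (within the scatter) likewise lies within the scatter. Compound 4 is therefore expected to come out within the scatter, the expected step being no change at the digits printed from compound 3 to compound 4 (within the scatter). Compound 4 is estimated at 100%, with a range from 90% to 100%.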

Compound 4, percent of the compound remaining: 83%
Beside the measured number, compound 4's estimate is 17 percentage points above it; the whole stated range lies above it.
By their numbers in this assay, from the lowest: compound 4; then compounds 1, 2 and 3 (each within the scatter of the next).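

In this assay, hydrogen in place of fluoro now registers, with a number 17 percentage points lower from compound 3 to compound 4 (beyond the scatter), so the outcome at this position depends on the group carried elsewhere in the compound: the same change on two cores in this assay, no change at the digits printed (within the scatter) from compound 1 to compound 2 and a number 17 percentage points higher (beyond the scatter) from compound 4 to compound 3, 17 percentage points apart, beyond the scatter of two such steps. Trifluoromethyl in place of chloro likewise registers once the fluoro is absent, with a number 17 percentage points lower from compound 1 to compound 4 (beyond the scatter), so the two exchanges cannot be read apart from each other: the same change on two cores in this assay, no change at the digits printed (within the scatter) from compound 2 to compound 3 and a number 17 percentage points lower (beyond the scatter) from compound 1 to compound 4, 17 percentage points apart, beyond the scatter of two such steps. The compounds shown leave open how a methoxy group or a nitrile at this place would read in this assay with trifluoromethyl present.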